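Aryl variation on the triazole nitrogen: compound 4

The compounds below may be only part of what the source reports. "The series", "measured", "known", "first", "only" and "open" are said of these compounds alone.

Three compounds share one core and differ only in the group on an aromatic nitrogen. Compound 1 `O=C1COc2ccc(-n3cc(C[C@H](O)COCCOC[C@@H](O)Cc4ccc(-c5ccccc5)cc4)nn3)cc2N1` gives, in a functional assay on HCT-116 cells (Homo sapiens) for inhibition, read by MTT assay, with a stated time of 72 h (on this read-out higher numbers stand for weaker inhibition of growth and lower numbers for stronger inhibition of growth), a value of 42500 nM. Compound 2 `O[C@H](COCCOC[C@@H](O)Cc1cn(-c2cccs2)nn1)Cc1ccc(-c2ccccc2)cc1` gives 33400 nM in this assay. Compound 3 `O[C@H](COCCOC[C@@H](O)Cc1cn(-c2ccc3c(c2)OCCO3)nn1)Cc1ccc(-c2ccccc2)cc1` gives 16500 nM in this assay. The steps run a 1.3-fold lower number from compound 1 to compound 2 (0.10 log units; within the scatter), a 2.6-fold lower number from compound 1 to compound 3 (0.41 log units; beyond the scatter) and a 2.0-fold lower number from compound 2 to compound 3 (0.31 log units; beyond the scatter); compound 3 thus stands lowest of the three, and its steps to the other two are both beyond the scatter, though modest.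

Compound 4 `O[C@H](COCCOC[C@@H](O)Cc1cn(-c2ccc3[nH]ccc3c2)nn1)Cc1ccc(-c2ccccc2)cc1` carries 1H-indol-5-yl in place of 2,3-dihydro-1,4-benzodioxin-6-yl on an aromatic nitrogen. Among the measured compounds shown here, the steps that bear on this are the two aryl exchanges on the same nitrogen, a 2.6-fold lower number from compound 1 to compound 3 (0.41 log units; beyond the scatter) and a 2.0-fold lower number from compound 2 to compound 3 (0.31 log units; beyond the scatter), both modest and both ending at compound 3; no measured step involves the indole. On this basis the expected step is small, a 1.0-fold lower number from compound 3 to compound 4 (0.01 log units; within the scatter), and in this assay compound 4 is expected to give about 16000 nM, within a range from 6000 nM to 40000 nM.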

Compound 4, concentration for 50% growth inhibition: 15500 nM
Beside the measured number, compound 4's estimate is 1.0-fold (0.01 log units) above it, within the range that was stated.
By their numbers in this assay, from the lowest: compounds 4 and 3 (each within the scatter of the next); then compounds 2 and 1 (each within the scatter of the next).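

On the aromatic nitrogen, the exchange of 2,3-dihydro-1,4-benzodioxin-6-yl for 1H-indol-5-yl gives a 1.1-fold lower number from compound 3 to compound 4 (0.03 log units; within the scatter) in this assay even though the six-membered non-aromatic ring and its hydrogen-bond acceptors leave and a five-membered aromatic ring with a hydrogen-bond donor enters. The indole also gives a 2.2-fold lower number from compound 2 to compound 4 (0.33 log units; beyond the scatter) and a 2.7-fold lower number from compound 1 to compound 4 (0.44 log units; beyond the scatter) as modest steps, so the lower numbers at this position do not depend on the group of compound 3 alone, and compound 1, which also carries a six-membered non-aromatic ring, stays on the higher side. Nothing at hand explains these differences. Open, going by these compounds, is whether the indole ring hydrogen matters, which 1-methylindol-5-yl on the same nitrogen would address. Also open, on these data alone, is whether a phenyl group bearing an amine or a carboxylic acid would move the number by more than these modest steps.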